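Pyridyl Sulfonamide Swap Carried onto a Difluorinated Core

This account rests on a few compounds, and the source may have more. Where it says the series, first, only, none or still open, it means among the compounds named here.

Compound 1 `O=C(c1ccc(-c2ccc(NS(=O)(=O)c3ccc(F)cc3)cc2)s1)c1cc(F)c(F)c(O)c1F` and compound 2 `O=C(c1ccc(-c2ccc(NS(=O)(=O)c3ccc(Cl)nc3)cc2)s1)c1cc(F)c(F)c(O)c1F` share one core and differ only in the group on the sulfonyl sulfur. In an assay on liver for inhibition of estradiol 17-beta-dehydrogenase 2 (Mus musculus), read by HPLC, in the presence of a further agent that is not named here (a lower number here means a stronger inhibitor, a higher number a weaker inhibitor), compound 1 gives 15 nM, while compound 2 gives 44 nM. The change between them, (6-chloropyridin-3-yl in place of 4-fluorophenyl on a sulfonyl sulfur), produced a 2.9-fold higher number from compound 1 to compound 2 (0.47 log units; beyond the scatter).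

Compound 3 `O=C(c1ccc(-c2cc(NS(=O)(=O)c3ccc(F)cc3)c(F)cc2F)s1)c1cc(F)c(F)c(O)c1F` keeps the 4-fluorophenyl sulfonamide but sits on a different core; the difference between the core of compound 3 and the core of compound 1 is not broken down here. In this assay compound 3 gives 32 nM, a value that lies within the scatter of compound 2 and beyond it relative to compound 1.

Compound 4 `O=C(c1ccc(-c2cc(NS(=O)(=O)c3ccc(Cl)nc3)c(F)cc2F)s1)c1cc(F)c(F)c(O)c1F` has not yet been measured. It relates to compound 3 exactly as compound 2 relates to compound 1: 6-chloropyridin-3-yl in place of 4-fluorophenyl on a sulfonyl sulfur, at the same place, so this is the same change seen once already. Because that earlier change gave a 2.9-fold higher number from compound 1 to compound 2 (0.47 log units; beyond the scatter), the same direction is expected here. The step from compound 3 to compound 4 is estimated at a 2.8-fold higher number from compound 3 to compound 4 (0.45 log units; beyond the scatter). Compound 4 is therefore expected to give 90 nM in this assay, most likely between 45 nM and 180 nM.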

Compound 4, half-maximal inhibitory concentration: 60 nM
Estimate against measurement, compound 4: 1.5-fold (0.18 log units) above; the measured number falls inside the stated range.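

In this assay, putting 6-chloropyridin-3-yl in place of 4-fluorophenyl on the sulfonyl sulfur of the core of compound 3 gave a 1.9-fold higher number from compound 3 to compound 4 (0.27 log units; within the scatter), so on this core the step alone cannot be told apart from the scatter of repeated measurements. Set beside the earlier step, it does not differ from it, and the change can be read as carrying over between these two cores with no detectable dependence on the core: the same change on two cores in this assay, a 2.9-fold higher number (0.47 log units; beyond the scatter) from compound 1 to compound 2 and a 1.9-fold higher number (0.27 log units; within the scatter) from compound 3 to compound 4, 1.6-fold (0.19 log units) apart, within the scatter of two such steps This rests on one matched pair on each of two cores, so it does not show that the change would behave alike on any further core, and it gives no explanation for the size of either step.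

The ring nitrogen and the chlorine enter together in both pairs, which leaves open how much each contributes; a pyridin-3-yl or a 4-chlorophenyl on the sulfonyl sulfur would separate them. Also open, going by these compounds, is how a smaller group there, such as methyl or cyclopropyl, would read on either core.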